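The source may hold more compounds than are shown below. What is called first, only, known or untested is meant among the compounds shown, and "the series" means these compounds.

Of the compounds shown here, three built on the same core have so far been tested in an assay on isolated protein for inhibition of mitogen-activated protein kinase kinase kinase 14 (Homo sapiens), read by ADP-Glo, with a stated time of 60 min, tested at 100 uM, in the presence of a further agent that is not named here; on this read-out higher numbers stand for more inhibition at the one concentration tested (going by the name of the read-out) and lower numbers for less inhibition. Compound 1 `O=C(Nc1cc(C(F)(F)F)cc(C(F)(F)F)c1)c1n[nH]nc1O` gives -9.5%, compound 2 `O=C(Nc1cc(C(F)(F)F)cc(C(F)(F)F)c1)c1nsnc1O` gives 4.34%, and compound 3 `Cn1cc(C(=O)Nc2cc(C(F)(F)F)cc(C(F)(F)F)c2)c(O)n1` gives 7.23%. Among these three numbers compound 3 stands highest, yet its gap to compound 2 lies within the scatter, so the two cannot be told apart; only compound 1 sits clearly lower. Compound 4 `O=C(Nc1cc(C(F)(F)F)cc(C(F)(F)F)c1)c1nonc1O` is now to be tested in this assay. It differs from compound 3 in one place: 4-hydroxy-1,2,5-oxadiazol-3-yl in place of 3-hydroxy-1-methyl-1H-pyrazol-4-yl on a carbonyl carbon. Two measured steps exchanged the group on the carbonyl carbon and so bear on this change: a number 16.7 percentage points higher from compound 1 to compound 3 (beyond the scatter) and a number 2.9 percentage points higher from compound 2 to compound 3 (within the scatter). A third, a number 13.8 percentage points higher from compound 1 to compound 2 (beyond the scatter), shows that trading one five-membered ring with 3 hetero atoms for another moved the number modestly. All three compounds remain close to zero at the single concentration tested, so each exchange of this ring has shifted the read-out modestly at most. Going from compound 3 to compound 4 is therefore expected to give a small step downward or none beyond the scatter, a number 4.2 percentage points lower from compound 3 to compound 4 (within the scatter). Compound 4 is estimated at 3%, within a range of -12% to 18%.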

Compound 4, a percentage reported as inhibition, at one concentration (the size of the read-out at that concentration, not a potency): 19.3%
Estimate against measurement, compound 4: 16.3 percentage points below; the whole stated range lies below it.
By their numbers in this assay, from the lowest: compound 1; then compounds 2 and 3 (each within the scatter of the next); then compound 4.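

The 4-hydroxy-1,2,5-oxadiazol-3-yl group lifts the read-out clear of every other group shown at this position on the carbonyl carbon: in this assay there is a number 12.1 percentage points higher from compound 3 to compound 4 (beyond the scatter), a number 15 percentage points higher from compound 2 to compound 4 (beyond the scatter) and a number 28.8 percentage points higher from compound 1 to compound 4 (beyond the scatter). The second of these steps is the most telling, since both groups have six heavy atoms and one five-membered aromatic ring with three hetero atoms, and they differ in that compound 2 has a sulfur atom where compound 4 has a second oxygen; so a change within the ring that leaves its size alone can move this number, though the steps remain modest and compound 4 reads only 19.3% at the one concentration tested. Nothing available explains why this ring stands apart from the others.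

Going by these compounds, all four rings carry a hydroxy group, so its own role remains open, and an amine or a carboxylic acid in its place would address that. A single-concentration number also leaves open how compound 4 would behave across a series of concentrations.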